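A few compounds are considered here, and "the series" means these few. Any claim that something is new, unique, unknown or untested is made for them only; others in the source may bear on it.

Compound 1 `COc1ccc(C(=O)c2ccc(OC)c3c2C=CC(C)(C)O3)c(NC(=O)CBr)c1`: 3290 nM
Compound 2 `COc1ccc(C(=O)c2ccc(OC)c3c2OC(C)(C)C=C3)c(NC(=O)CO)c1`: 320 nM

In a functional assay on MCF7 cells (Homo sapiens) for antiproliferative activity, read by MTT assay, with a stated time of 48 h (on this read-out higher numbers stand for weaker inhibition and lower numbers for stronger inhibition), compound 1 gives 3290 nM and compound 2 gives 320 nM. The number for compound 1 is the higher of the two, and the gap between them lies beyond the scatter. Compound 3 `CCNCC(=O)Nc1cc(OC)ccc1C(=O)c1ccc(OC)c2c1C=CC(C)(C)O2` keeps the core of compound 1 and carries ethylamino in place of bromo on a saturated chain carbon bound to a carbonyl carbon. Going by the values given here, no measured step isolates this change, so the expectation is tentative. It rests only on compound 2 at 320 nM, which shows that lower numbers occur here. The expected step in this assay is a 2.7-fold lower number from compound 1 to compound 3 (0.44 log units; beyond the scatter), towards stronger inhibition. The estimated value for compound 3 is 1200 nM, with an expected range from 300 nM to 4500 nM.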

Compound 3, half-maximal inhibitory concentration: 7230 nM
Estimate against measurement, compound 3: 6.0-fold (0.78 log units) below; the whole stated range lies below it.
By their numbers in this assay, from the lowest: compound 2; then compound 1; then compound 3.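

In this assay, ethylamino in place of bromo on a saturated chain carbon bound to a carbonyl carbon gives a 2.2-fold higher number from compound 1 to compound 3 (0.34 log units; beyond the scatter), a modest step towards weaker inhibition. Activity at this position therefore does not depend on bromo alone, since compound 3 still gives a measurable number with ethylamino there. Nothing available explains the direction or size of this step. On these data alone, what a longer amine such as propylamino, or a cyclic amine such as morpholine, would give at this place remains open. So does the effect of a carboxylic acid there on the core of compound 1.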